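Replacing the aryl ring on the core: compound 4

The source may report more compounds than this note shows. Statements on the series, on what has been measured and on what is new or still open speak of the compounds shown alone.

Three compounds have been tested in a functional assay on PC-12 cells (Rattus norvegicus) for cytotoxicity, read by MTT assay, with stated times of 2 h and 24 h, tested at 5 uM; a higher number here means a stronger effect of the compound at the concentration tested, a lower number a weaker effect:
compound 1, `Oc1cc(C(F)(F)F)ccc1-c1nc(-c2ccccc2O)n(-c2cccc(Cl)c2)n1`, gives 92.7%;
compound 2, `Oc1cc(C(F)(F)F)ccc1-c1nc(-c2ccccc2O)n(-c2cccc(C(F)(F)F)c2)n1`, gives 92.2%;
compound 3, `COc1cccc(-n2nc(-c3ccc(C(F)(F)F)cc3O)nc2-c2ccccc2O)c1`, gives 96.8%.

Compound 3 holds the highest of the three numbers, yet its gaps to the others, a number 4.1 percentage points higher from compound 1 to compound 3 (within the scatter) and a number 4.6 percentage points higher from compound 2 to compound 3 (within the scatter), sit within the scatter, so the three are not told apart. Compound 4, `Oc1cc(C(F)(F)F)ccc1-c1nc(-c2ccccc2O)n(-c2ccc(Cl)cc2Cl)n1`, differs from compound 3 in one place: 2,4-dichlorophenyl in place of 3-methoxyphenyl on an aromatic nitrogen. The earlier steps shown here on that same ring, a number 0.5 percentage points lower from compound 1 to compound 2 (within the scatter) together with the two just named, were all within the scatter, so no step beyond the scatter is expected here either, giving a number 3.8 percentage points lower from compound 3 to compound 4 (within the scatter). Compound 4 is therefore estimated at 93%, with a range from 84% to 99%.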

Compound 4, a percentage reported as activity, at one concentration (the size of the read-out at that concentration, not a potency): 86.7%
Compound 4: the middle estimate sits 6.3 percentage points above what was measured; the range from low to high includes it.
By their numbers in this assay, from the lowest: compounds 4, 2, 1 and 3 (each within the scatter of the next, the first and the last beyond it).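

For the compounds shown here, on the aromatic nitrogen, 2,4-dichlorophenyl produces the first step beyond the scatter at this position (a number 10.1 percentage points lower from compound 3 to compound 4 (beyond the scatter)), while the same group stays within the scatter against the other two rings (a number 5.5 percentage points lower from compound 2 to compound 4 (within the scatter)) (a number 6 percentage points lower from compound 1 to compound 4 (within the scatter)). The read-out in this assay can therefore shift with this ring, but the separation is modest and holds only for this one pair. No measurement given here accounts for the difference. The compounds shown carry only substituted phenyl rings at this position. As far as these compounds go, how a benzyl group, or a phenyl ring bearing an amine or a carboxylic acid, would read remains open.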